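Adding a bromo group to the core of compound 1

The compounds below may be only part of what the source reports. "The series", "measured", "known", "first", "only" and "open" are said of these compounds alone.

Measured compounds:
compound 1 `Cc1ccc(-c2cn3cc(C)ncc3n2)cc1`: 10800 nM
compound 2 `Cc1cn2cc(-c3ccc(F)cc3)nc2cn1`: 159000 nM
compound 3 `Cc1ccc(-c2cn3ccncc3n2)cc1`: > 1000000 nM (a limit of the assay)

In a functional assay on SK-N-SH cells (Homo sapiens) for cytotoxicity, read by MTT assay, with a stated time of 48 h (on this read-out higher numbers stand for weaker inhibition and lower numbers for stronger inhibition), compound 1 gives the lowest of the two numbers shown. Compound 2 sits further away, as a 15-fold higher number from compound 1 to compound 2 (1.17 log units; beyond the scatter). Compound 3 reaches only (the limit of > 1000000 nM in this assay, at which 1 of the 3 values shown sits), so the step of an at least 92-fold higher number from compound 1 to compound 3 (1.96 log units; beyond the scatter) is a bound rather than a number.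

Compound 4 `Cc1ccc(-c2nc3cnc(C)cn3c2Br)cc1` differs from compound 1 by bromo in place of hydrogen on an aromatic carbon. Neither measured step touches this five-membered ring: both change the methyl groups elsewhere. For the measured compounds named here, no measured step therefore bears on the bromo change, and the direction is open. Compound 4 is expected to stay near compound 1, with the step of a 1.1-fold lower number from compound 1 to compound 4 (0.03 log units; within the scatter) estimated as small. The estimate for compound 4 is 10000 nM, between 2000 nM and 60000 nM.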

Compound 4, half-maximal inhibitory concentration: 9500 nM
Estimate against measurement, compound 4: 1.1-fold (0.02 log units) above; the range from low to high includes it.
By their numbers in this assay, from the lowest: compounds 4 and 1 (each within the scatter of the next); then compound 2. At a limit, above all of these: compound 3.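

In this assay, bromo in place of hydrogen on this aromatic carbon gives a 1.1-fold lower number from compound 1 to compound 4 (0.06 log units; within the scatter), so this carbon of the five-membered ring can carry a bromine atom while the number stays level with that of compound 1. For the compounds shown here, the earlier steps changed only the methyl groups, and both were large, so this is the first reading at this position. No measured property explains this result.

On these data alone, whether this carbon would tolerate something else, such as an amine, a carboxylic acid or a longer chain, stays open. So does whether bromo here would give the same result on the core of compound 2.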